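This account rests on a few compounds, and the source may have more. Where it says the series, first, only, none or still open, it means among the compounds named here.

Measured so far in an ADME assay (liver) for metabolic stability, with Liver microsome (Homo sapiens) as the target, read by LC-MS, using microsomes, tested at 1 uM; a higher number here means faster removal of the compound, a lower number slower removal:
- compound 1, `CNc1nc(NCCCN(C)C)c2sc(-c3ccc(-n4cccn4)cc3)cc2n1`: 18.4 uL/min
- compound 2, `CNc1nc(NCCCN(C)C)c2sc(-c3ccc(N4CCNCC4)cc3)cc2n1`: 36 uL/min
- compound 3, `CNc1nc(NCCCN(C)C)c2sc(-c3cncnc3)cc2n1`: < 17 uL/min

All three share one core and differ only in the aromatic group carried on it. Compound 1 and compound 2 give plain numbers, and the step of a 2.0-fold higher number from compound 1 to compound 2 (0.29 log units; within the scatter) is too small to count as a real difference. For compound 3 the assay reports no number, only a limit: compound 3 sits at the limit of < 17 uL/min in this assay, at which 1 of the 3 values shown sits, so its clearance is known only as lying under that line.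

Compound 4, `CNc1nc(NCCCN(C)C)c2sc(-c3ccccc3)cc2n1`, is not yet measured. It differs from compound 3 in one place: phenyl in place of pyrimidin-5-yl on an aromatic carbon. Going by the values given here, no measured step involves this exchange, so nothing here shows directly what it does. Among the compounds with values here, the one measured step, at a similar position, stayed within the scatter, and the values of compound 1 and compound 3 show that two different groups at that place both sit at the low end.

Compound 4 is therefore expected to stay in the same region, perhaps slightly higher, at about 22 uL/min, with a range of 10 uL/min to 50 uL/min. The expected step is an at least 1.2-fold higher number from compound 3 to compound 4 (0.11 log units; that floor lies within the scatter), and it is not expected to exceed the scatter clearly.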

Compound 4, intrinsic clearance in a liver preparation (reported as CLH), per the amount of preparation that the assay uses in the Liver microsome assay: 5 uL/min
Compound 4: the middle estimate sits 4.4-fold (0.64 log units) above what was measured; the measured number lies below the stated range.
By their numbers in the Liver microsome assay, from the lowest: compound 4; then compounds 1 and 2 (each within the scatter of the next).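

In the Liver microsome assay, taking the group off the phenyl ring gives a 7.2-fold lower number from compound 2 to compound 4 (0.86 log units; beyond the scatter) for piperazin-1-yl and a 3.7-fold lower number from compound 1 to compound 4 (0.57 log units; beyond the scatter) for 1H-pyrazol-1-yl. Going by these compounds alone, both steps lie beyond the scatter, whereas the one earlier step, between the two substituted phenyl compounds, did not, so this is the first readable sign that a further group on that phenyl ring goes with faster removal of compounds. The steps between compound 3 and compound 4 cannot be read in either assay, so the exchange of pyrimidin-5-yl for phenyl stays without a size, and in the clearance assay the obstacle is this: the limit of < 17 uL/min in the Liver microsome assay, at which 1 of the 4 values shown sits.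

As far as these compounds go, in a physicochemical assay for solubility, at pH 2 (a higher number here means a more soluble compound, a lower number a less soluble compound), compound 4 gives > 100 ug/mL, which is a limit, and compound 3, in a separate reading of the physicochemical assay, gives 214 ug/mL, so how the two compare in solubility stays open. Also open, from the compounds shown here alone, is whether a smaller group on the phenyl ring, such as a fluorine atom or a methoxy group, would keep the clearance of compound 4 or move it towards that of compound 1 and compound 2.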